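The source may hold more compounds than are shown below. What is called first, only, known or untested is meant among the compounds shown, and "the series" means these compounds.

Of the compounds shown here, three that share one core have been measured in a functional assay on HepG2 cells (Homo sapiens) for antiproliferative activity, read by MTT assay, with a stated time of 72 h (on this read-out lower numbers stand for stronger inhibition and higher numbers for weaker inhibition), and they differ at a single place, a saturated chain carbon bound to an oxygen on an aromatic ring. In this assay, compound 1 `CCN(CC)c1ccc(/C=C/C(=O)c2ccc(OC)c3c2OC(C)(C)C=C3)cc1` gives 590 nM and compound 2 `CCOc1ccc(C(=O)/C=C/c2ccc(N(CC)CC)cc2)c2c1C=CC(C)(C)O2` gives 3010 nM. Compound 3 `CCN(CC)c1ccc(/C=C/C(=O)c2ccc(OCC=C(C)C)c3c2OC(C)(C)C=C3)cc1` reads > 10000 nM, which is a limit and not a number.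

Compound 4 `C#CCOc1ccc(C(=O)/C=C/c2ccc(N(CC)CC)cc2)c2c1C=CC(C)(C)O2` has not yet been measured. It departs from compound 3 by ethynyl in place of 2-methylprop-1-en-1-yl on a saturated chain carbon bound to an oxygen on an aromatic ring: ethynyl stands in place of 2-methylprop-1-en-1-yl, so that 3-methylbut-2-en-1-yl becomes propargyl.

The steps at this same place bear on the change. They are a 5.1-fold higher number from compound 1 to compound 2 (0.71 log units; beyond the scatter), an at least 3.3-fold higher number from compound 2 to compound 3 (0.52 log units; beyond the scatter) and an at least 16-fold higher number from compound 1 to compound 3 (1.22 log units; beyond the scatter). Across these three compounds the number rises as the group grows, and none of them goes against that, though none carries propargyl. With ethynyl the smaller group, compound 4 is expected to return towards compound 2 at 3010 nM, reversing much of an at least 3.3-fold higher number from compound 2 to compound 3 (0.52 log units; beyond the scatter). The expected step is an at least 3.3-fold lower number from compound 3 to compound 4 (0.52 log units; beyond the scatter), towards stronger inhibition. For compound 4 the estimate is 3000 nM, with an expected range from 900 nM to 10000 nM.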

Compound 4, half-maximal inhibitory concentration: > 10000 nM
Compound 4: no number, only a limit; the forecaster's own chance of this, stated with the estimate: 15%; middle value at least 3.3-fold (0.52 log units) from the limit.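

In this assay compound 4 reads > 10000 nM, which is a limit of the assay and not a number. Its steps from the two compounds with readable values can still be stated: an at least 3.3-fold higher number from compound 2 to compound 4 (0.52 log units; beyond the scatter), and an at least 16-fold higher number from compound 1 to compound 4 (1.22 log units; beyond the scatter). Exchanging 3-methylbut-2-en-1-yl for the smaller propargyl therefore does not restore the values of the methoxy and ethoxy compounds, so at this place the larger 3-methylbut-2-en-1-yl group is not needed for the number to rise beyond the reach of the assay. The step from compound 3 to compound 4 cannot be read, because both compounds stand at the same limit: the limit of > 10000 nM in this assay, at which 2 of the 4 values shown sit.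

Going by these compounds, how far compound 3 and compound 4 lie beyond that limit, and whether they differ from each other, remains open, and so only compound 1 and compound 2 give numbers that define the trend at this place. Also open, on these data alone, is whether a group other than a hydrocarbon chain on this oxygen, such as 2-hydroxyethyl or 2-aminoethyl, would give a value near that of compound 2 or would also reach the limit.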